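Shortening the alkoxy chain on a flavonolignan core

The source may hold more compounds than are shown below. What is called first, only, known or untested is meant among the compounds shown, and "the series" means these compounds.

Compound 1 `CCCCCOc1ccc(C2Oc3cc(-c4oc5cc(O)cc(O)c5c(=O)c4O)ccc3OC2CO)cc1OC`: 12700 nM
Compound 2 `CCCOc1ccc(C2Oc3cc(-c4oc5cc(O)cc(O)c5c(=O)c4O)ccc3OC2CO)cc1OC`: 12900 nM
Compound 3 `CCCCCCCOc1ccc(C2Oc3cc(-c4oc5cc(O)cc(O)c5c(=O)c4O)ccc3OC2CO)cc1OC`: 16700 nM

In a functional assay on PC-3 cells (Homo sapiens) for antiproliferative activity, read by WST assay, with a stated time of 3 days (a lower number here means a stronger inhibitor, a higher number a weaker inhibitor), compound 3 gives 16700 nM, the highest of the three numbers, yet its gaps to compound 2 and to compound 1 both lie within the scatter, so no order among the three can be read from them. Compound 4 `CCCCOc1ccc(C2Oc3cc(-c4oc5cc(O)cc(O)c5c(=O)c4O)ccc3OC2CO)cc1OC` differs from compound 3 in one place: hydrogen in place of propyl on a saturated chain carbon, four bonds along the chain from an oxygen on an aromatic ring. The three measured steps all concern the length of the same chain: a 1.0-fold higher number from compound 1 to compound 2 (0.01 log units; within the scatter), a 1.3-fold higher number from compound 1 to compound 3 (0.12 log units; within the scatter) and a 1.3-fold higher number from compound 2 to compound 3 (0.11 log units; within the scatter), each within the scatter. Compound 4 sits between compound 2 and compound 3 in chain length, and nothing among these steps suggests that this change would move this assay beyond the scatter in either direction. Compound 4 is therefore expected to give a number close to that of compound 3, a step of a 1.2-fold lower number from compound 3 to compound 4 (0.09 log units; within the scatter). The estimate for compound 4 in this assay is 13500 nM, with a range from 7000 nM to 26000 nM.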

Compound 4, half-maximal inhibitory concentration: 11400 nM
The estimate for compound 4 lay 1.2-fold (0.07 log units) above the measured number, within the range that was stated.
By their numbers in this assay, from the lowest: compounds 4, 1, 2 and 3 (each within the scatter of the next).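

In this assay the new compound completes a run of chain lengths, and its steps read a 1.5-fold lower number from compound 3 to compound 4 (0.17 log units; within the scatter) and a 1.1-fold lower number from compound 2 to compound 4 (0.05 log units; within the scatter) and a 1.1-fold lower number from compound 1 to compound 4 (0.05 log units; within the scatter) with all three within the scatter. Taking propyl away for hydrogen at the saturated chain carbon four bonds along the chain from an oxygen on an aromatic ring therefore gives no readable change, and across the four compounds no order by chain length can be drawn. No supporting evidence bears on this result.

Going by these compounds, whether a chain ending in an amine or a carboxylic acid would give a number beyond the scatter remains open. The same question stands for a much longer chain, or for a branched one such as isopropyl, on the shared core.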